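Ester variation on the shared core

This account rests on a few compounds, and the source may have more. Where it says the series, first, only, none or still open, it means among the compounds named here.

Compound 1 `CC(=O)Oc1ccccc1C(=O)O[C@H]1CO[C@H]2[C@@H]1OC[C@H]2OC(C)=O` and compound 2 `CCCCC(=O)O[C@@H]1CO[C@H]2[C@@H]1OC[C@@H]2OC(=O)c1ccccc1OC(C)=O` share one core and differ at a single ester. In an ADME assay on a cell-free system (plasma, Homo sapiens) for metabolic stability, with Plasma (Rattus norvegicus) as the target, read by HPLC, at pH 7.4 (a lower number here means that the compound disappears faster, a higher number that the compound lasts longer), compound 1 gives 0.0608 h, and compound 2 gives 0.0198 h. For the measured compounds named here, the step of a 3.1-fold lower number from compound 1 to compound 2 (0.49 log units; beyond the scatter) is the only measured step so far, and it leaves compound 2 with the lowest of the two numbers, compound 1 standing above it. Compound 3 `COc1ccccc1C(=O)O[C@@H]1CO[C@H]2[C@@H]1OC[C@@H]2OC(=O)c1ccccc1OC(C)=O` is not yet measured; it differs from compound 2 by 2-methoxyphenyl in place of butyl on a carbonyl carbon. Going by the values given here, no measured step bears on this exchange: the one step known concerns a chain lengthened on a saturated carbon, not an aromatic ring entering on the carbonyl carbon, so it gives no direct guide to size or direction in this assay. With nothing to lean on, a step close to none beyond the scatter is expected, a 1.8-fold higher number from compound 2 to compound 3 (0.25 log units; within the scatter), with wide uncertainty either way. Compound 3 is therefore estimated at 0.035 h, in the range 0.01 h to 0.12 h.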

Compound 3, half-life: 0.0578 h
The estimate for compound 3 lay 1.7-fold (0.22 log units) below the measured number, and the stated range covers the measured number.
By their numbers in this assay, from the lowest: compound 2; then compounds 3 and 1 (each within the scatter of the next).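

In this assay, 2-methoxyphenyl in place of butyl on the carbonyl carbon gives a 2.9-fold higher number from compound 2 to compound 3 (0.47 log units; beyond the scatter) at this ester position, so replacing butyl with this aromatic group changes the half-life measurably. Against methyl, the same group gives a 1.1-fold lower number from compound 1 to compound 3 (0.02 log units; within the scatter) and cannot be told apart from it, which leaves butyl as the only one of the three groups that stands apart. The order therefore does not follow the heavy-atom count of the group, and no available evidence explains the result.

Still open, going by these compounds, is whether a longer chain such as hexyl would stay with butyl, or whether unsubstituted phenyl would stay with 2-methoxyphenyl. On these data alone, the effect of an amine on the acyl group at this position also remains open.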